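This account rests on a few compounds, and the source may have more. Where it says the series, first, only, none or still open, it means among the compounds named here.

Measured compounds:
- Compound 1, `O=C(O)c1c(Cn2c(=O)n(C3CC3)c3ccncc32)nc2cc(Cl)ccn12`: in an ADME assay on HEp-2 cells (Homo sapiens) for cytotoxicity, read by CCK-8 assay, with a stated time of 6 days (on this read-out lower numbers stand for higher toxicity in this test and higher numbers for lower toxicity in this test), compound 1 gives > 100000 nM, which is a limit of the assay rather than a number.
- Compound 2, `CS(=O)(=O)CCNC(=O)c1c(Cn2c(=O)n(C3CC3)c3ccncc32)nc2cc(Cl)ccn12`: in this assay compound 2 gives > 100000 nM, again a limit of the assay.
- Compound 3, `O=c1n(Cc2nc3cc(Cl)ccn3c2NC2CCCCC2)c2cnccc2n1C1CC1`: in this assay compound 3 gives > 100000 nM, also a limit of the assay.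

Compound 3 therefore stands where every measured compound stands: at the limit, with no number to place it higher or lower than compound 1 or compound 2. The three measured steps give no readable size: a step that the two limits leave unreadable from compound 1 to compound 2, a step that the two limits leave unreadable from compound 1 to compound 3 and a step that the two limits leave unreadable from compound 2 to compound 3, and the reason is the limit of > 100000 nM in this assay, at which 3 of the 3 values shown sit.

Compound 4 is `O=c1n(Cc2nc3cc(Cl)ccn3c2CNCCO)c2cnccc2n1C1CC1`. It differs from compound 3 in one place: ((2-hydroxyethyl)amino)methyl in place of cyclohexylamino on an aromatic carbon. For the measured compounds named here, none of the measured steps bears on this exchange in a readable way, since all of them sit between two limits. With nothing pointing either way, the expectation is that compound 4, like compound 3, shows no toxicity within the range of this assay, and the estimated step that the limit leaves unreadable from compound 3 to compound 4 is expected to be none beyond the scatter. The estimate for compound 4 is 150000 nM, with a range from 50000 nM to 500000 nM.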

Compound 4, half-maximal cytotoxic concentration: > 100000 nM
Compound 4 ended at the assay's limit; the forecaster's own chance of this, stated with the estimate: 80%; the middle value is on the limit's open side.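

No size can be read for the steps linking compound 4 to compound 1, compound 2 and compound 3, because all of these compounds sit at the same limit: the limit of > 100000 nM in this assay, at which 4 of the 4 values shown sit.

The compounds shown leave open whether any of them differ in toxicity in this assay, and which exchange on the aromatic carbon, if any, would give a readable value.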